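Swapping the Triazole Substituent in a Bromophenol Series

The source may report more compounds than this note shows. Statements on the series, on what has been measured and on what is new or still open speak of the compounds shown alone.

Compound 1 `C=C1C[C@]23C[C@@]1(O)CC[C@H]2c1ccc(O)c(C)c1[C@@H]3Cn1cc(-c2ccccn2)nn1` gives only a limit in a functional assay on MCF7 cells (Homo sapiens) for cytotoxicity, read by MTT assay, with a stated time of 4 days; a higher number here means a weaker inhibitor, a lower number a stronger inhibitor: > 20000 nM.
Compound 2 `Cc1ccc(S(=O)(=O)Oc2ccc3c(c2C)[C@H](Cn2cc(-c4ccc(Cl)cc4)nn2)[C@@]24CC(=O)[C@@](C)(CC[C@@H]32)C4)cc1` also gives only a limit in this assay: > 20000 nM.
Compound 3 `C=C1C[C@]23C[C@@]1(O)CC[C@H]2c1cc(Br)c(O)c(C)c1[C@@H]3Cn1cc(-c2ccccn2)nn1` likewise gives only a limit in this assay: > 20000 nM.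

None of the three measured compounds yields a number in this assay; every value shown sits at the assay limit, as the limit of > 20000 nM in this assay, at which 3 of the 3 values shown sit, records. Among the measured compounds shown here, compound 3 therefore cannot be ranked against compound 1 or compound 2 on these numbers, and the one single-point step, bromo in place of hydrogen on an aromatic carbon, is unreadable from both ends: a step that the two limits leave unreadable from compound 1 to compound 3.

Compound 4 `C=C1C[C@]23C[C@@]1(O)CC[C@H]2c1cc(Br)c(O)c(C)c1[C@@H]3Cn1cc(-c2ccc(Cl)cc2)nn1` differs from compound 3 in one place: 4-chlorophenyl in place of pyridin-2-yl on an aromatic carbon. For the measured compounds named here, no measured step covers this exchange. Compound 2, which carries the same 4-chlorophenyl group on its triazole but differs from compound 3 in other places too, shows only a limit, so the shown data give no indication of a gain in potency.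

Compound 4 is therefore expected to remain at the limit of this assay, with an estimated value of 30000 nM, in a range from 10000 nM to 100000 nM. The expected step from compound 3 to compound 4 is thus a step that the limit leaves unreadable from compound 3 to compound 4, not beyond the scatter.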

Compound 4, half-maximal inhibitory concentration: 10200 nM
Estimate against measurement, compound 4: 2.9-fold (0.47 log units) above; the measured number falls inside the stated range.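

Among the compounds shown here, compound 4 is the only one of the four compounds to give a number rather than a limit, so this aromatic carbon of the five-membered aromatic ring with 3 nitrogen is a place where a single exchange can bring a compound into the readable range of this assay. Putting 4-chlorophenyl in place of pyridin-2-yl gives an at least 1.9-fold lower number from compound 3 to compound 4 (0.29 log units; that floor lies within the scatter), so only a floor for this step is known, and it does not by itself establish a real gain. The other three compounds offer no number to set beside it: the limit of > 20000 nM in this assay, at which 3 of the 4 values shown sit.

On these data alone, whether the chlorine or the carbon-only ring matters more remains open, and a plain phenyl at this place would help separate the two. As far as these compounds go, how far this place tolerates change also remains open, for example with a phenyl carrying an amine or a carboxylic acid.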